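The compounds below may be only part of what the source reports. "The series", "measured", "known", "first", "only" and "open" are said of these compounds alone.

Compound 3 `CC(C)(C)C1=NN(c2ccccc2F)C(c2ccc(O)cc2)C1` gives 57.6% in an assay on isolated protein for inhibition of protein kinase C zeta type (Homo sapiens), with a stated time of 4 min, tested at 62.5 uM (on this read-out higher numbers stand for more inhibition at the one concentration tested (going by the name of the read-out) and lower numbers for less inhibition), and stands lowest of the three measured compounds, below compound 1 `CC(C)(C)C1=NN(c2ccc(Br)cc2)C(c2ccc(O)cc2)C1` with 93.2% and compound 2 `CC(C)(C)C1=NN(c2cccc(F)c2)C(c2ccc(O)cc2)C1` with 98.1%. The steps of a number 35.6 percentage points lower from compound 1 to compound 3 (beyond the scatter) and a number 40.5 percentage points lower from compound 2 to compound 3 (beyond the scatter) were both large, while a number 4.9 percentage points higher from compound 1 to compound 2 (within the scatter) was within the scatter. Compound 4 `CC(C)(C)C1=NN(c2ccc(F)cc2F)C(c2ccc(O)cc2)C1` differs from compound 3 by fluoro in place of hydrogen on an aromatic carbon, so that 2-fluorophenyl becomes 2,4-difluorophenyl. Going by the values given here, no measured step adds a fluoro on this aromatic carbon; the steps to compound 3 only show that the 2-fluorophenyl group, which compound 4 keeps, goes with low inhibition. A moderate rise is therefore expected, a number 7.4 percentage points higher from compound 3 to compound 4 (within the scatter), with wide uncertainty. Compound 4 is estimated at 65%, within 38% to 90%.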

Compound 4, a percentage reported as inhibition, at one concentration (the size of the read-out at that concentration, not a potency): 68%
Compound 4: the middle estimate sits 3 percentage points below what was measured; low and high end bracket the measured number.
By their numbers in this assay, from the lowest: compound 3; then compound 4; then compounds 1 and 2 (each within the scatter of the next).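

In this assay fluoro in place of hydrogen on the aromatic carbon para to a large group brings a number 10.4 percentage points higher from compound 3 to compound 4 (beyond the scatter) as a modest gain, the first measured sign that a second substituent on the 2-fluorophenyl ring can add inhibition. The gain is only partial: 2,4-difluorophenyl still shows a number 30.1 percentage points lower from compound 2 to compound 4 (beyond the scatter) and a number 25.2 percentage points lower from compound 1 to compound 4 (beyond the scatter) and so remains short of 3-fluorophenyl and 4-bromophenyl. No measurement at hand gives a reason for these steps. From the compounds shown here alone, whether chloro or methoxy on that same carbon would raise the number likewise stays open, as does how unsubstituted phenyl would compare with these rings.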